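A few compounds are considered here, and "the series" means these few. Any claim that something is new, unique, unknown or untested is made for them only; others in the source may bear on it.

Three compounds share one core and differ in the group on a saturated chain carbon bound to an aromatic carbon. In an ADME assay on cells (Macrophage, Homo sapiens) for inhibition (on this read-out higher numbers stand for lower toxicity in this test and lower numbers for higher toxicity in this test), compound 1 `Brc1ccc(Cc2nnc(Cn3nnc4ccccc43)o2)cc1` gives > 100000 nM, which is a limit of the assay and not a number. In this assay compound 2 `Fc1cccc(Cc2nnc(Cn3nnc4ccccc43)o2)c1` gives > 100000 nM, again a limit. In this assay compound 3 `COc1ccc(Cc2nnc(Cn3nnc4ccccc43)o2)cc1` gives > 100000 nM, also a limit. Compound 3 therefore stands at the limit of > 100000 nM in this assay, at which 3 of the 3 values shown sit, and no exact number places it any closer.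

Compound 4 `COc1ccccc1Cc1nnc(Cn2nnc3ccccc32)o1` has not yet been measured. It carries 2-methoxyphenyl in place of 4-methoxyphenyl on a saturated chain carbon bound to an aromatic carbon, with the same atoms joined differently (2-methoxyphenyl in place of 4-methoxyphenyl on a saturated chain carbon bound to an aromatic carbon).

Among the measured compounds shown here, three measured steps bear on this change: a step that the two limits leave unreadable from compound 1 to compound 2, a step that the two limits leave unreadable from compound 1 to compound 3 and a step that the two limits leave unreadable from compound 2 to compound 3. None of them has a size that can be read, and none of the three compounds has left the limit. With compound 3 at > 100000 nM, no step beyond the usual scatter is expected in this assay. The expected step is a number no higher from compound 3 to compound 4 (the limit leaves the size open). Compound 4 is estimated at 100000 nM, with an expected range of 40000 nM to 200000 nM, and it may well be reported only as a limit.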

Compound 4, half-maximal cytotoxic concentration: > 100000 nM
Compound 4: no number, only a limit (the forecaster's own chance of this, stated with the estimate: 85%); the middle value sits exactly at the limit.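

In this assay compound 4 gives > 100000 nM, which is a limit and not a number. Its steps from compound 1, compound 2 and compound 3 therefore cannot be read: the limit of > 100000 nM in this assay, at which 4 of the 4 values shown sit.

The compounds shown leave open how far apart their true values lie, and whether 2-methoxyphenyl and 4-methoxyphenyl differ at all on this read-out.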